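Swapping a Branched Chain for a Methylbenzyl Group

The compounds below may be only part of what the source reports. "The series", "measured", "known", "first", "only" and "open" are said of these compounds alone.

Compound 1, `CCCCn1ccc2cc(/C(C)=C/C(=O)Nc3ccccc3OCCCC(=O)O)ccc21`: in an assay on Prostate gland for inhibition of steroid 5-alpha-reductase (Rattus norvegicus) (on this read-out higher numbers stand for weaker inhibition and lower numbers for stronger inhibition), compound 1 gives 43 nM.
Compound 2, `CCCCC(CC)n1ccc2cc(/C(C)=C/C(=O)Nc3ccccc3OCCCC(=O)O)ccc21`: in this assay compound 2 gives 7.1 nM.
Compound 3, `CCCCCC(CCCCC)n1ccc2cc(/C(C)=C/C(=O)Nc3ccccc3OCCCC(=O)O)ccc21`: in this assay compound 3 gives 25 nM.

Compound 3 carries the second highest number of the three; its gap to compound 1 is within the scatter, while compound 2 sits clearly lower. The step to compound 4, `C/C(=C\C(=O)Nc1ccccc1OCCCC(=O)O)c1ccc2c(ccn2Cc2ccc(C)cc2)c1`, changes the group on the aromatic nitrogen: 4-methylbenzyl in place of 1-pentylhexyl on an aromatic nitrogen. All three measured steps touch this same position: a 6.1-fold lower number from compound 1 to compound 2 (0.78 log units; beyond the scatter), a 1.7-fold lower number from compound 1 to compound 3 (0.24 log units; within the scatter) and a 3.5-fold higher number from compound 2 to compound 3 (0.55 log units; beyond the scatter). Within the data shown here, they show that the group here shifts the number by modest amounts in either direction, but no measured compound carries an aromatic group at this place, so the direction is uncertain. Compound 4 is therefore expected to show a 1.3-fold lower number from compound 3 to compound 4 (0.10 log units; within the scatter). Compound 4 is estimated at 20 nM in this assay, with a range from 6 nM to 70 nM.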

Compound 4, half-maximal inhibitory concentration: 88 nM
Compound 4: the middle estimate sits 4.4-fold (0.64 log units) below what was measured; the whole stated range lies below it.
By their numbers in this assay, from the lowest: compound 2; then compounds 3 and 1 (each within the scatter of the next); then compound 4.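

Compared with the alkyl groups, 4-methylbenzyl on the aromatic nitrogen brings a 3.5-fold higher number from compound 3 to compound 4 (0.55 log units; beyond the scatter) and a 12-fold higher number from compound 2 to compound 4 (1.09 log units; beyond the scatter) and also a 2.0-fold higher number from compound 1 to compound 4 (0.31 log units; beyond the scatter) in this series. This makes compound 4 the weakest inhibitor of the four, so the first ring-bearing group at this place does worse than each of the three chains shown. From the compounds shown here alone, whether this holds for every ring-bearing group remains open, since plain benzyl or a benzyl carrying a chlorine or methoxy group could give a different number. Nothing available explains why this change raises the number.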